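Aroyl variation on a shared core: compound 3 to compound 4

The compounds below may be only part of what the source reports. "The series", "measured", "known", "first", "only" and "open" are said of these compounds alone.

Compound 1, `O=C(Nc1cccc(-c2oc3cc(-c4ccc(F)cc4)ccc3c(=O)c2O)c1)c1ccc(Cl)cc1`, gives 11000 nM in a functional assay on HepG2 cells (Homo sapiens) for antiproliferative activity, read by CCK-8 assay, with a stated time of 72 h; a higher number here means a weaker inhibitor, a lower number a stronger inhibitor. Compound 2, `O=C(Nc1cccc(-c2oc3cc(-c4ccc(F)cc4)ccc3c(=O)c2O)c1)c1cccc(F)c1`, gives 15500 nM. Compound 3, `O=C(Nc1cccc(-c2oc3cc(-c4ccc(F)cc4)ccc3c(=O)c2O)c1)c1ccc(Cl)nc1`, gives 4610 nM.

Compound 3 shows the lowest number of the three, through a 2.4-fold lower number from compound 1 to compound 3 (0.38 log units; beyond the scatter) and a 3.4-fold lower number from compound 2 to compound 3 (0.53 log units; beyond the scatter), both modest but beyond the scatter, while a 1.4-fold higher number from compound 1 to compound 2 (0.15 log units; within the scatter) stays within it. Compound 4, `O=C(Nc1cccc(-c2oc3cc(-c4ccc(F)cc4)ccc3c(=O)c2O)c1)c1cnc(Cl)nc1Cl`, carries 2,4-dichloropyrimidin-5-yl in place of 6-chloropyridin-3-yl on a carbonyl carbon. For the measured compounds named here, the steps that bear on it are the two into compound 3, where exchanging a phenyl for a heteroaryl on the carbonyl carbon lowered the number modestly. Going by the values given here, no measured step covers a second ring nitrogen or a second chlorine, so the expectation is a number close to that of compound 3, with at most a small further lowering. Compound 4 is therefore expected at 3500 nM, with a range from 1500 nM to 9000 nM. The estimate means a step of a 1.3-fold lower number from compound 3 to compound 4 (0.12 log units; within the scatter).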

Compound 4, half-maximal inhibitory concentration: > 100000 nM
Compound 4 ended at the assay's limit; the forecaster's own chance of this, stated with the estimate: 5%; middle value at least 28-fold (1.45 log units) away from the limit.
By their numbers in this assay, from the lowest: compound 3; then compounds 1 and 2 (each within the scatter of the next). At a limit, above all of these: compound 4.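

For the compounds shown here, replacing 6-chloropyridin-3-yl with 2,4-dichloropyrimidin-5-yl on the carbonyl carbon gives an at least 21-fold higher number from compound 3 to compound 4 (1.33 log units; beyond the scatter), the first large step at this place, so a heteroaryl ring here does not in itself lower the number. The phenyl compounds also stand clearly on the other side of this change, with an at least 9.0-fold higher number from compound 1 to compound 4 (0.95 log units; beyond the scatter) and an at least 6.4-fold higher number from compound 2 to compound 4 (0.80 log units; beyond the scatter). The value of compound 4 in this assay is a limit, not a number: the limit of > 100000 nM in this assay, at which 1 of the 4 values shown sits.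

The second ring nitrogen and the second chlorine enter together, and the compounds shown do not separate them. Also open, on these data alone, is how an unsubstituted pyrimidin-5-yl group or a 6-aminopyridin-3-yl group would read in this place.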